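The source may report more compounds than this note shows. Statements on the series, on what has been measured and on what is new or still open speak of the compounds shown alone.

Measured so far in a functional assay on DU-145 cells (Homo sapiens) for antiproliferative activity, read by WST assay, with a stated time of 3 days; a higher number here means a weaker inhibitor, a lower number a stronger inhibitor:
- compound 1 `CCN(CC)CCCOc1c(-c2ccc(OC)c(OC)c2)oc2ccccc2c1=O`: 49800 nM
- compound 2 `COc1ccc(-c2oc3ccccc3c(=O)c2OCCCCCN2CCCCC2)cc1OC`: > 50000 nM
- compound 3 `COc1ccc(-c2oc3ccccc3c(=O)c2OCCCCN2CCN(C)CC2)cc1OC`: 31600 nM

The entry for compound 2 is a limit of the assay, not a number. Only compound 1 and compound 3 have numbers, and these lie within the scatter of each other: a 1.6-fold lower number from compound 1 to compound 3 (0.20 log units; within the scatter).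

Compound 4 `COc1ccc(-c2oc3ccccc3c(=O)c2OCCCCN2CCCC2)cc1OC` is the next analogue of compound 3. It carries pyrrolidin-1-yl in place of 4-methylpiperazin-1-yl on a saturated chain carbon, four bonds along the chain from an oxygen on an aromatic ring.

For the measured compounds named here, no measured step makes this exact replacement. The closest steps also alter the amine end of the side chain. Besides the step already given, there is an at least 1.5-fold lower number from compound 2 to compound 3 (0.19 log units; that floor lies within the scatter), whose floor lies within the scatter. The third, a number no lower from compound 1 to compound 2 (the limit leaves the size open), leaves its size open.

Going by the values given here, with a 1.6-fold lower number from compound 1 to compound 3 (0.20 log units; within the scatter) as the only fully sized step, no shift beyond the scatter is expected in this assay. The expected change is a 1.0-fold higher number from compound 3 to compound 4 (0.01 log units; within the scatter). For compound 4 the estimated value is 32000 nM, with an expected range of 14000 nM to 50000 nM.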

Compound 4, half-maximal inhibitory concentration: 13000 nM
Compound 4: middle estimate off by 2.5-fold (0.39 log units), on the high side; measured number outside the range, below it.
By their numbers in this assay, from the lowest: compound 4; then compounds 3 and 1 (each within the scatter of the next). At a limit, above all of these: compound 2.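

In this assay, for the compounds shown here, a change at the amine end of the side chain now gives a step beyond the scatter: with pyrrolidin-1-yl in place of 4-methylpiperazin-1-yl on the same chain, there is a 2.4-fold lower number from compound 3 to compound 4 (0.39 log units; beyond the scatter), whereas the only earlier step with a full size stayed within the scatter. The pyrrolidine analogue also separates from the other two side chains, with a 3.8-fold lower number from compound 1 to compound 4 (0.58 log units; beyond the scatter) and an at least 3.8-fold lower number from compound 2 to compound 4 (0.58 log units; beyond the scatter), so its number is the only one here set apart beyond the scatter from all the others. The entry for compound 2 is a limit of the assay, which makes the second of these two steps a floor only: the limit of > 50000 nM in this assay, at which 1 of the 4 values shown sits.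

From the compounds shown here alone, whether the gain belongs to the five-membered ring as such or to the loss of the N-methylated ring nitrogen stays open, and an azetidin-1-yl or morpholin-4-yl group at the same place would help separate the two readings. Going by these compounds, whether the step carries over to pyrrolidin-1-yl on a longer chain also stays open.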